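A chlorine moves the aryl substituent on the sulfonamide

This account rests on a few compounds, and the source may have more. Where it says the series, first, only, none or still open, it means among the compounds named here.

compound 1 `O=C1NCCN1c1ccc(S(=O)(=O)Nc2ccc(C3CCCCC3)cc2)cc1`: > 1000 nM in a functional assay on HT-29 cells (Homo sapiens) for antiproliferative activity, read by sulforhodamine B assay, with a stated time of 48 h (a lower number here means a stronger inhibitor, a higher number a weaker inhibitor), a limit of the assay
compound 2 `CCc1ccc(NS(=O)(=O)c2ccc(N3CCNC3=O)cc2)cc1`: 660 nM
compound 3 `O=C1NCCN1c1ccc(S(=O)(=O)Nc2ccc(OC(F)F)cc2)cc1`: 650 nM

Compound 2 holds the higher of the two numbers shown, yet the other lies only a 1.0-fold lower number from compound 2 to compound 3 (0.01 log units; within the scatter). The value of compound 1 is a limit, (the limit of > 1000 nM in this assay, at which 1 of the 3 values shown sits). Compound 4 `O=C1NCCN1c1ccc(S(=O)(=O)Nc2cccc(Cl)c2)cc1` differs from compound 2 by 3-chlorophenyl in place of 4-ethylphenyl on a sulfonamide nitrogen. Going by the values given here, no measured step touches a 3-chlorophenyl: an at least 1.5-fold lower number from compound 1 to compound 2 (0.18 log units; that floor lies within the scatter) and an at least 1.5-fold lower number from compound 1 to compound 3 (0.18 log units; that floor lies within the scatter) each start from a limit, and a 1.0-fold lower number from compound 2 to compound 3 (0.01 log units; within the scatter) stays within the scatter. No step beyond the scatter is therefore expected in this assay. Compound 4 is estimated at 700 nM, ranging from 300 nM to 1600 nM. That estimate means a 1.1-fold higher number from compound 2 to compound 4 (0.03 log units; within the scatter) is expected.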

Compound 4, half-maximal inhibitory concentration: 55 nM
Compound 4: middle estimate off by 13-fold (1.10 log units), on the high side; the measured number lies below the stated range.
By their numbers in this assay, from the lowest: compound 4; then compounds 3 and 2 (each within the scatter of the next). At a limit, above all of these: compound 1.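

In this assay, the sulfonamide nitrogen responds strongly to its aryl group: 3-chlorophenyl in place of 4-ethylphenyl gives a 12-fold lower number from compound 2 to compound 4 (1.08 log units; beyond the scatter), the only step shown that is beyond the scatter. The earlier steps either stayed within the scatter or started from a limit, so this position had shown no clear response until now. Nothing measured here accounts for this step. Going by these compounds, it remains open whether the chlorine itself carries the step, and whether a bromine or a methoxy group in its place would do the same.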